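A hydroxy group replacing the pyrazolyl on the amide nitrogen

This account rests on a few compounds, and the source may have more. Where it says the series, first, only, none or still open, it means among the compounds named here.

Three amides built on the shared core of compound 1 `Cc1ccc(OCC(=O)N(Cc2cccs2)c2cccnc2)cc1` have been measured in an assay on HEK293 cells for agonist activity at transient receptor potential cation channel subfamily M member 8 (Homo sapiens), read by fluorescence and calcium flux, with a stated time of 15 min; on this read-out lower numbers stand for an effect already at smaller amounts and higher numbers for an effect only at larger amounts of compound. Compound 1 gives 198 nM. Compound 2 `Cc1ccc(OCC(=O)N(Cc2cccs2)c2ccccn2)cc1` gives 200 nM, and the step of a 1.0-fold higher number from compound 1 to compound 2 (0.00 log units; within the scatter) is within the scatter. Compound 3 `Cc1ccc(OCC(=O)N(Cc2cccs2)c2c(C)n[nH]c2C)cc1` gives 0.3 nM, the lowest number of the three, and its steps to the others are large: a 660-fold lower number from compound 1 to compound 3 (2.82 log units; beyond the scatter) and a 670-fold lower number from compound 2 to compound 3 (2.82 log units; beyond the scatter), both beyond the scatter, so compound 3 is the most potent of the measured set.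

Compound 4 `Cc1ccc(OCC(=O)N(O)Cc2cccs2)cc1` differs from compound 3 in one place: hydroxy in place of 3,5-dimethyl-1H-pyrazol-4-yl on an amide-type nitrogen. Among the compounds with values here, no measured pair shows a hydroxy on this nitrogen, so the two steps leading into compound 3 are the only guide. They show that the number on this read-out depends strongly on what sits on the amide-type nitrogen, with the 3,5-dimethyl-1H-pyrazol-4-yl standing far apart from either pyridyl. Removing that group entirely is therefore expected to cost much of the potency of compound 3, and a large step upward in this assay is expected, a 1000-fold higher number from compound 3 to compound 4 (3.00 log units; beyond the scatter), with wide uncertainty. For compound 4 the estimated value is 300 nM, with a range from 20 nM to 5000 nM.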

Compound 4, half-maximal effective concentration: 8000 nM
Compound 4: middle estimate off by 27-fold (1.43 log units), on the low side, outside the stated range (above it).
By their numbers in this assay, from the lowest: compound 3; then compounds 1 and 2 (each within the scatter of the next); then compound 4.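

Within the data shown here, compound 4 shows that the position has a much wider span than the earlier compounds revealed. In this assay, hydroxy on the amide-type nitrogen stands far from the 3,5-dimethyl-1H-pyrazol-4-yl (a 27000-fold higher number from compound 3 to compound 4 (4.43 log units; beyond the scatter)) and also clearly apart from the two pyridyl groups (a 40-fold higher number from compound 2 to compound 4 (1.60 log units; beyond the scatter); a 40-fold higher number from compound 1 to compound 4 (1.61 log units; beyond the scatter)), so the pyridyl compounds, which had looked like the poor end of the series, now sit in the middle and compound 4 is the least potent of the four. Among these compounds, all three ring-bearing compounds give lower numbers than the one compound with no ring at this place, and none of the four goes against that, but nothing available here explains the differences.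

On these data alone, whether the high number of compound 4 reflects the loss of a ring or the hydroxy itself stays open, and a methyl group, an amine or the plain amide hydrogen on this nitrogen would help to separate those two readings. Also open, as far as these compounds go, is how much of the low number of compound 3 rests on its two methyl groups, a question that an unsubstituted 1H-pyrazol-4-yl would address.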